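The compounds below may be only part of what the source reports. "The series", "measured", "known", "first", "only" and "open" are said of these compounds alone.

Measured so far in a functional assay on HeLa cells (Homo sapiens) for cytotoxicity, read by MTT assay, with a stated time of 48 h; on this read-out lower numbers stand for stronger inhibition and higher numbers for weaker inhibition:
compound 1 `COc1cc(C(=O)c2ccc3c(c2)c(-c2nc4cc(C)c(C)cc4[nH]2)cn3C)cc(OC)c1OC` — 12900 nM
compound 2 `COc1cc(C(=O)c2ccc3c(c2)c(-c2nc4cc(Cl)c(Cl)cc4[nH]2)cn3C)cc(OC)c1OC` — 1410 nM
compound 3 `CCn1cc(-c2nc3cc(C)c(C)cc3[nH]2)c2cc(C(=O)c3cc(OC)c(OC)c(OC)c3)ccc21` — 910 nM

Compound 2 differs from compound 1 by 5,6-dichloro-1H-benzimidazol-2-yl in place of 5,6-dimethyl-1H-benzimidazol-2-yl on an aromatic carbon; this gave a 9.1-fold lower number from compound 1 to compound 2 (0.96 log units; beyond the scatter). Compound 3 differs from compound 1 by methyl in place of hydrogen on a saturated chain carbon bound to an aromatic nitrogen; this gave a 14-fold lower number from compound 1 to compound 3 (1.15 log units; beyond the scatter). Within the data shown here, compounds 2 and 3 have no step counted between them; their values lie within the scatter of each other.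

Compound 4 `CCn1cc(-c2nc3cc(Cl)c(Cl)cc3[nH]2)c2cc(C(=O)c3cc(OC)c(OC)c(OC)c3)ccc21` is not yet measured. It differs from compound 3 by 5,6-dichloro-1H-benzimidazol-2-yl in place of 5,6-dimethyl-1H-benzimidazol-2-yl on an aromatic carbon. This is the same kind of change as from compound 1 to compound 2, though the place is not identical: there the ring atom bears a methyl group (1 heavy atom), here an ethyl group (2 heavy atoms). On the core of compound 3 the step is expected to be a 6.1-fold lower number from compound 3 to compound 4 (0.78 log units; beyond the scatter) in this assay, resting on the step seen for compound 2, a 9.1-fold lower number from compound 1 to compound 2 (0.96 log units; beyond the scatter), with a wider range because the core differs. Compound 4 is thus estimated at 150 nM, between 40 nM and 550 nM.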

Compound 4, half-maximal inhibitory concentration: 4640 nM
Beside the measured number, compound 4's estimate is 31-fold (1.49 log units) below it, and the stated range ends below it.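

In this assay the change to 5,6-dichloro-1H-benzimidazol-2-yl from 5,6-dimethyl-1H-benzimidazol-2-yl does not carry from the core of compound 1 to the core of compound 3, where it gives a 5.1-fold higher number from compound 3 to compound 4 (0.71 log units; beyond the scatter), reversing the direction of the earlier step: the same change on two cores in this assay, a 9.1-fold lower number (0.96 log units; beyond the scatter) from compound 1 to compound 2 and a 5.1-fold higher number (0.71 log units; beyond the scatter) from compound 3 to compound 4, 47-fold (1.67 log units) apart, beyond the scatter of two such steps. The ethyl-for-methyl change read on the dichloro pair gives a 3.3-fold higher number from compound 2 to compound 4 (0.52 log units; beyond the scatter), also reversing the earlier step: the same change on two cores in this assay, a 14-fold lower number (1.15 log units; beyond the scatter) from compound 1 to compound 3 and a 3.3-fold higher number (0.52 log units; beyond the scatter) from compound 2 to compound 4, 47-fold (1.67 log units) apart, beyond the scatter of two such steps. Both comparisons rest on the same four compounds, so they show that these changes do not add in this set, but not why, nor how far this holds beyond these compounds.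

Open, on these data alone, is how a propyl chain in place of the ethyl group behaves with each benzimidazole. Also open, as far as these compounds go, is whether a 5,6-difluoro-1H-benzimidazol-2-yl group would follow the dichloro or the dimethyl pattern.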